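Taking the chloro off compound 3

The source may report more compounds than this note shows. Statements on the series, on what has been measured and on what is new or still open speak of the compounds shown alone.

In an ADME assay on HEK293 cells (Homo sapiens) for cytotoxicity, read by resazurin assay, with a stated time of 48 h (on this read-out higher numbers stand for lower toxicity in this test and lower numbers for higher toxicity in this test), compound 1 `COc1ccc(S(=O)(=O)Nc2ccc(-c3nc4cc(NS(=O)(=O)c5ccc(OC)cc5)ccc4o3)cc2)cc1` gives 48000 nM and compound 2 `COc1ccc(S(=O)(=O)Nc2ccc3oc(-c4ccc(NC(=O)c5cccc(C)c5[N+](=O)[O-])cc4)nc3c2)cc1` gives 12000 nM. Compound 3 `O=C(Nc1ccc(Sc2nc3ccccc3s2)c(Cl)c1)c1cccc(Br)c1O`, built on a different core from the other two, gives 68000 nM. Among the compounds with values here, that number lies within the usual scatter of the one for compound 1, and it is clearly higher than the one for compound 2, which means lower toxicity in this test than compound 2 shows.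

Compound 4 `O=C(Nc1ccc(Sc2nc3ccccc3s2)cc1)c1cccc(Br)c1O` differs from compound 3 in a single place: hydrogen in place of chloro on an aromatic carbon. In words, hydrogen stands in place of chloro on an aromatic carbon.

Within the data shown here, no measured step touches this chloro. Among the measured compounds shown here, the only step available is a 4.0-fold lower number from compound 1 to compound 2 (0.60 log units; beyond the scatter), where (3-methyl-2-nitrophenyl)carbonyl replaces (4-methoxyphenyl)sulfonyl on a nitrogen on an aromatic ring. That exchange swaps a whole large group on another core, so it offers only a loose yardstick, and it is still a modest step. Exchanging one atom is expected to move the number less, with no clear direction and nothing beyond the scatter. The estimated step is a 1.1-fold lower number from compound 3 to compound 4 (0.05 log units; within the scatter). Compound 4 is expected to give about 60000 nM, with an estimated range of 25000 nM to 130000 nM.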

Compound 4, half-maximal cytotoxic concentration: 33000 nM
The estimate for compound 4 lay 1.8-fold (0.26 log units) above the measured number; measured number inside the range.
By their numbers in this assay, from the lowest: compound 2; then compounds 4, 1 and 3 (each within the scatter of the next, the first and the last beyond it).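

In this assay the exchange of chloro for hydrogen gives a 2.1-fold lower number from compound 3 to compound 4 (0.31 log units; beyond the scatter) and so shows that this one atom, on an aromatic carbon ortho to a large group and meta to a large group, counts on its own: compound 4, which lacks it, shows higher toxicity in this test than compound 3. Within the data shown here, the only earlier step swapped a whole large group on another core, whereas here a single heavy atom leaves, with no ring and no hydrogen-bond donor or acceptor, and the number still moves beyond the usual scatter, although the step stays modest. Nothing measured here explains why the number moves when the chloro goes.

The compounds shown leave open whether chloro is special at this carbon or whether a fluoro, a methyl or a methoxy in the same place would hold the number up as well. They also leave open whether the same exchange would move the number in the same direction on a different core, such as that of compound 1.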